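This account rests on a few compounds, and the source may have more. Where it says the series, first, only, none or still open, it means among the compounds named here.

Compound 3 `CC(C)(C)c1ccc(S(=O)(=O)N[C@H]2CCN(Cc3cc4[nH]cccc-4n3)C2=O)cc1` is examined in an assay on isolated protein for inhibition of coagulation factor X (Oryctolagus cuniculus), tested at 1 uM (a higher number here means more inhibition at the concentration tested (going by the name of the read-out), a lower number less inhibition), where compound 3 gives 22%. Among the three measured compounds this is the lowest number, but it lies within the scatter of both neighbours: compound 1 `O=C1[C@@H](NS(=O)(=O)c2cc3ccc(Cl)nc3s2)CCN1Cc1cc2[nH]cccc-2n1` gives 23% in this assay, and compound 2 `O=C1[C@@H](NS(=O)(=O)c2nc3cc(Cl)ccc3[nH]2)CCN1Cc1cc2c[nH]ccc-2n1` gives 31%.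

Compound 4 `O=C1[C@@H](NS(=O)(=O)c2nc3cc(Cl)ccc3[nH]2)CCN1Cc1cc2[nH]cccc-2n1` has not yet been measured. It differs from compound 3 in one place: 5-chloro-1H-benzimidazol-2-yl in place of 4-(tert-butyl)phenyl on a sulfonyl sulfur. Within the data shown here, the one measured step that bears on this kind of change is the swap on the same sulfonyl sulfur between compound 1 and compound 3, which gave a number 1 percentage points lower from compound 1 to compound 3 (within the scatter). That step, exchanging one aromatic group for another of the same size, stayed within the scatter. Compound 2 carries the same 5-chloro-1H-benzimidazol-2-yl group that enters in compound 4, but on a different core, so its value can only be taken as a hint that this group is compatible with inhibition in the same range.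

On this basis, the step of a number 5 percentage points higher from compound 3 to compound 4 (within the scatter) is expected to stay within the scatter, with no clear direction. Compound 4 is therefore estimated to give 27% in this assay, with a range from 14% to 40%.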

Compound 4, a percentage reported as inhibition, at one concentration (the size of the read-out at that concentration, not a potency): 14%
Estimate against measurement, compound 4: 13 percentage points above, and the stated range covers the measured number.
By their numbers in this assay, from the lowest: compounds 4, 3, 1 and 2 (each within the scatter of the next, the first and the last beyond it).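

In this assay, the exchange on the sulfonyl sulfur again stays within the scatter, with a number 8 percentage points lower from compound 3 to compound 4 (within the scatter) and a number 9 percentage points lower from compound 1 to compound 4 (within the scatter), so this read-out does not separate 5-chloro-1H-benzimidazol-2-yl, 4-(tert-butyl)phenyl and the sulfonyl substituent of compound 1, even though 5-chloro-1H-benzimidazol-2-yl carries a hydrogen-bond donor and acceptor that 4-(tert-butyl)phenyl lacks. With 5-chloro-1H-benzimidazol-2-yl held constant, exchanging the group on the saturated chain carbon bound to an amide-type nitrogen in a ring gives a number 17 percentage points lower from compound 2 to compound 4 (beyond the scatter), a modest step beyond the scatter and the first sign that this other place can register in the read-out. No available measurement accounts for that step.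

On these data alone, this step rests on a single pair, so it remains open whether the same exchange would register with 4-(tert-butyl)phenyl or the sulfonyl substituent of compound 1 on the sulfonyl sulfur. Also open, as far as these compounds go, is whether a cyclohexyl ring or a short alkyl chain on the sulfonyl sulfur, or an amine or a carboxylic acid on its aromatic group, would move the number beyond the scatter.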